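Chlorophenyl position swap on the styryl flavone series

This account rests on a few compounds, and the source may have more. Where it says the series, first, only, none or still open, it means among the compounds named here.

Compound 1 `CN1CC[C@H](c2c(O)cc(O)c3c(=O)cc(/C=C/c4ccc(Cl)cc4)oc23)[C@H](O)C1` gives 8000 nM in a functional assay on HL-60 cells (Homo sapiens) for inhibition, read by MTT assay, with a stated time of 48 h (a lower number here means a stronger inhibitor of growth, a higher number a weaker inhibitor of growth), and it stands level with compound 2 `CN1CC[C@H](c2c(O)cc(O)c3c(=O)cc(/C=C/c4cccc(F)c4)oc23)[C@H](O)C1` at 8000 nM and compound 3 `CN1CC[C@H](c2c(O)cc(O)c3c(=O)cc(/C=C/c4ccccc4F)oc23)[C@H](O)C1` at 8000 nM. The steps of no change at the digits printed from compound 1 to compound 2 (within the scatter) and no change at the digits printed from compound 1 to compound 3 (within the scatter) show no movement, nor does no change at the digits printed from compound 2 to compound 3 (within the scatter). Compound 4 `CN1CC[C@H](c2c(O)cc(O)c3c(=O)cc(/C=C/c4ccccc4Cl)oc23)[C@H](O)C1` is not yet measured; the change from compound 1 is 2-chlorophenyl in place of 4-chlorophenyl on a double-bonded chain carbon bound to a double-bonded chain carbon. Within the data shown here, the steps that bear on it are no change at the digits printed from compound 1 to compound 3 (within the scatter) and no change at the digits printed from compound 2 to compound 3 (within the scatter), both flat, so no step beyond the scatter is expected in this assay for this move. The estimated step is no change at the digits printed from compound 1 to compound 4 (within the scatter). Compound 4 is expected to give 8000 nM, with a range from 4000 nM to 16000 nM.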

Compound 4, concentration for 50% growth inhibition: 9000 nM
For compound 4 the middle estimate is 1.1-fold (0.05 log units) below the measured one, within the range that was stated.
By their numbers in this assay, from the lowest: compounds 1, 2, 3 and 4 (each within the scatter of the next).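

In this assay the chloro group reads the same at both printed positions on the phenyl ring (a 1.1-fold higher number from compound 1 to compound 4 (0.05 log units; within the scatter)). Chloro in place of fluoro on an aromatic carbon also leaves the reading flat (a 1.1-fold higher number from compound 3 to compound 4 (0.05 log units; within the scatter)), as does the step that changes both halogen and position (a 1.1-fold higher number from compound 2 to compound 4 (0.05 log units; within the scatter)), so neither separates these four compounds. No evidence is at hand on what lies behind this flat reading.

Open, going by these compounds, is whether an amine or a carboxylic acid on the phenyl ring, or a longer chain in place of the ethenyl link, would shift the number.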